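The source may hold more compounds than are shown below. What is called first, only, known or untested is meant among the compounds shown, and "the series" means these compounds.

Compound 1 `CC(=O)c1ccc2[nH]c(-c3ccccc3)nc2c1` is the reference. In an ADME assay on Vero cells (Chlorocebus sabaeus) for cytotoxicity, read by MTT assay, with a stated time of 96 h (on this read-out lower numbers stand for higher toxicity in this test and higher numbers for lower toxicity in this test), compound 1 gives only a limit, > 100000 nM. Compound 2 `C/C(=N\O)c1ccc2[nH]c(-c3ccccc3)nc2c1` also reaches only the limit in this assay, > 100000 nM. Compound 3 `C/C(=N\NC(N)=S)c1ccc2[nH]c(-c3ccccc3)nc2c1` again stops at the limit in this assay, > 100000 nM. The steps a step that the two limits leave unreadable from compound 1 to compound 2, a step that the two limits leave unreadable from compound 1 to compound 3 and a step that the two limits leave unreadable from compound 2 to compound 3 therefore carry no readable size because of the limit of > 100000 nM in this assay, at which 3 of the 3 values shown sit. Compound 4 `CC(=O)c1ccc2c(c1)nc(-c1ccccc1)n2C1CCCCC1` differs from compound 1 by cyclohexyl in place of hydrogen on an aromatic nitrogen. Among the compounds with values here, none of the measured steps touches the aromatic nitrogen, and all sit at the limit, leaving no measured guide for this change. The expected step of a number no higher from compound 1 to compound 4 (the limit leaves the size open) is accordingly taken as none beyond the scatter. Compound 4 is expected to give about 100000 nM, within 30000 nM to 300000 nM, most probably once more as a limit.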

Compound 4, half-maximal cytotoxic concentration: 80000 nM
Beside the measured number, compound 4's estimate is 1.3-fold (0.10 log units) above it, and the stated range covers the measured number.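

In this assay, the aromatic nitrogen now has a measured change: cyclohexyl in place of hydrogen gives an at least 1.2-fold lower number from compound 1 to compound 4 (0.09 log units; that floor lies within the scatter). Compound 4 is the only compound shown that gives a number rather than a limit, so this change brings the read-out into the range where a value can be stated. The full size of the step stays open because the comparison rests on a limit: the limit of > 100000 nM in this assay, at which 3 of the 4 values shown sit.

The compounds shown leave open how a methyl group or a longer chain on this aromatic nitrogen would read. They also leave open whether a cyclohexyl ring carrying an amine would read like cyclohexyl itself.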